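Aryl hydrazone variation on the shared core: compound 4

A few compounds are considered here, and "the series" means these few. Any claim that something is new, unique, unknown or untested is made for them only; others in the source may bear on it.

In a functional assay on MKN-45 cells (Homo sapiens) for cytotoxicity, read by MTT assay, with a stated time of 72 h (a higher number here means a weaker inhibitor, a lower number a stronger inhibitor), the three measured compounds stand as follows.
Compound 1 `CN(C)CCn1cnnc1-c1cc(Oc2ccc(NC(=O)N/N=C/c3ccc(O)c(Br)c3)cc2F)ccn1` gives 1860 nM.
Compound 2 `COc1ccc(/C=N/NC(=O)Nc2ccc(Oc3ccnc(-c4nncn4CCN(C)C)c3)c(F)c2)c(OC)c1OC` gives 2020 nM.
Compound 3 `CN(C)CCn1cnnc1-c1cc(Oc2ccc(NC(=O)N/N=C/c3ccc(F)cc3F)cc2F)ccn1` gives 810 nM.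

Compound 3 holds the lowest number of the three: a 2.3-fold lower number from compound 1 to compound 3 (0.36 log units; beyond the scatter) and a 2.5-fold lower number from compound 2 to compound 3 (0.40 log units; beyond the scatter), while compound 1 and compound 2 lie within the scatter of each other (a 1.1-fold higher number from compound 1 to compound 2 (0.04 log units; within the scatter)). Compound 4 `CN(C)CCn1cnnc1-c1cc(Oc2ccc(NC(=O)N/N=C/c3cccc(Cl)c3Cl)cc2F)ccn1` differs from compound 3 only in 2,3-dichlorophenyl in place of 2,4-difluorophenyl on a carbon with a double bond to nitrogen. All measured steps exchange the group on this same carbon, and each moved this assay by no more than a modest amount; none swaps one dihalogenated phenyl for another. Compound 4 is therefore expected to land close to compound 3, with a slight rise as the more likely side, a 1.4-fold higher number from compound 3 to compound 4 (0.13 log units; within the scatter). The estimate for compound 4 is 1100 nM, within 450 nM to 2700 nM.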

Compound 4, half-maximal inhibitory concentration: 51 nM
The estimate for compound 4 lay 22-fold (1.33 log units) above the measured number; measured number outside the range, below it.
By their numbers in this assay, from the lowest: compound 4; then compound 3; then compounds 1 and 2 (each within the scatter of the next).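

In this assay, for the compounds shown here, the carbon with a double bond to nitrogen proves far more sensitive than the earlier steps suggested: a 16-fold lower number from compound 3 to compound 4 (1.20 log units; beyond the scatter), a large step between two dihalogenated phenyl groups that match in every computed count. The 2,3-dichlorophenyl group also stands well clear of the other two aryl groups, with a 40-fold lower number from compound 2 to compound 4 (1.60 log units; beyond the scatter) and a 36-fold lower number from compound 1 to compound 4 (1.56 log units; beyond the scatter). Nothing available explains the gap between the two halogenated groups.

From the compounds shown here alone, whether the gain follows the chlorine or its placement stays open; 2,4-dichlorophenyl and 2,3-difluorophenyl on this carbon would separate the two. A 2,3-dimethylphenyl group would test whether halogen is needed at all.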